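From nitrile chains to a carboxy group on a shared core

This account rests on a few compounds, and the source may have more. Where it says the series, first, only, none or still open, it means among the compounds named here.

In a functional assay on A-427 cells (Homo sapiens) for cytotoxicity, read by colorimetric assay and MTT assay (a lower number here means a stronger inhibitor, a higher number a weaker inhibitor), the values so far are these:
compound 1 `COc1ccc(-c2cc3c(OC)cc(OC)cc3n(CC#N)c2=O)cc1` gives 10000 nM
compound 2 `COc1ccc(-c2cc3c(OC)cc(OC)cc3n(CCCC#N)c2=O)cc1` gives 10000 nM

Compound 2 stands level with compound 1 on these numbers. For the measured compounds named here, the only measured step is no change at the digits printed from compound 1 to compound 2 (within the scatter) and it swaps cyano for 2-cyanoethyl on the same chain. The change to compound 3 `COc1ccc(-c2cc3c(OC)cc(OC)cc3n(CC(=O)O)c2=O)cc1` is carboxy in place of 2-cyanoethyl on a saturated chain carbon bound to an aromatic nitrogen and it sets carboxy in place of 2-cyanoethyl on a saturated chain carbon bound to an aromatic nitrogen. The measured step bears on the nitrile-bearing chain only. Going by the values given here, no measured compound carries carboxy, so the data give no direct reading of that group. Starting from compound 2 at 10000 nM as the only anchor, no shift beyond the scatter is expected in this assay for now. The estimated move is no change at the digits printed from compound 2 to compound 3 (within the scatter) with no direction favoured. For compound 3 the estimate is 10000 nM with an expected range from 4000 nM to 20000 nM in this reading.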

Compound 3, half-maximal inhibitory concentration: 10000 nM
Compound 3: middle estimate and measured number agree at the digits printed, within the range that was stated.
By their numbers in this assay, from the lowest: compounds 1, 2 and 3 (each within the scatter of the next).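

In this assay, the chain on a saturated chain carbon bound to an aromatic nitrogen now ends in carboxy rather than a nitrile, and the reading is no change at the digits printed from compound 2 to compound 3 (within the scatter); set against the cyano-bearing chain, it is no change at the digits printed from compound 1 to compound 3 (within the scatter). The earlier pair varied only a nitrile-bearing chain, whereas this change also replaces the nitrile end with a different group, one that brings in a hydrogen-bond donor, and the three compounds still cannot be told apart at this position. No supporting data bear on why these readings coincide.

From the compounds shown here alone, it stays open whether an amine or a primary amide at the end of this chain, or carboxy on a longer chain, would read differently in this assay. The compounds shown also leave open whether any change on the shared core itself would separate them.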